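The source may report more compounds than this note shows. Statements on the series, on what has been measured and on what is new or still open speak of the compounds shown alone.

Measured so far:
- compound 1 `COc1cccc(C(=O)N2CCCCC2CCOc2ccc(Cl)c(Cl)c2)c1`: 501 nM
- compound 2 `O=C(c1ccccc1-c1ccccc1)N1CCCCC1CCOc1ccc(F)cc1`: 20 nM
- compound 3 `O=C(c1ccccc1-c1ccccc1)N1CCCC[C@H]1CCOc1ccc(F)cc1F`: 0.794 nM

In a functional assay on CHO cells for antagonist activity at Orexin receptor type 2 (Homo sapiens), read by FLIPR (a lower number here means a stronger inhibitor, a higher number a weaker inhibitor), compound 3 gives 0.794 nM, the lowest number of the three. Compound 2 gives 20 nM and compound 1 gives 501 nM; both gaps from compound 3 lie beyond the scatter, so compound 3 is the strongest inhibitor here.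

Compound 4 `O=C(NC[C@@H]1CCCCN1C(=O)c1ccccc1-c1ccccc1)Nc1ccccc1` is not yet measured. It differs from compound 3 in one place: (phenylcarbamoyl)amino in place of (2,4-difluorophenoxy)methyl on a saturated chain carbon bound to a saturated ring carbon. Going by the values given here, all three measured compounds carry the aryloxymethyl chain, and none carries a urea, so no step among them covers this exchange. A weakening beyond the scatter is expected, since every measured compound owes its number to the ether chain. Compound 4 is expected to give 30 nM, with a range of 4 nM to 300 nM. The expected step is a 38-fold higher number from compound 3 to compound 4 (1.58 log units; beyond the scatter).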

Compound 4, inhibition constant: 5.01 nM
Beside the measured number, compound 4's estimate is 6.0-fold (0.78 log units) above it, within the range that was stated.
By their numbers in this assay, from the lowest: compound 3; then compound 4; then compound 2; then compound 1.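

At this position on a saturated chain carbon bound to a saturated ring carbon, the ether chain is not essential for strong inhibition: in this assay, (phenylcarbamoyl)amino in place of (2,4-difluorophenoxy)methyl gives a 6.3-fold higher number from compound 3 to compound 4 (0.80 log units; beyond the scatter), a modest loss. The exchange keeps the heavy-atom count and the aromatic ring while adding hydrogen-bond donors, and activity stays in the low nanomolar range. Nothing available explains why the step is this small.

As far as these compounds go, whether the urea hydrogens contribute remains open, and a methyl group on a urea nitrogen would test this. The effect of fluorine on the urea phenyl ring, or of a longer chain before the urea, is also unknown.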